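The source may hold more compounds than are shown below. What is called first, only, known or untested is meant among the compounds shown, and "the series" means these compounds.

Compound 1 `Fc1cccc(Nc2c(-c3ccccn3)nc3ccccn23)c1` is a shared core that carries no substituent on its fused ring system. In an ADME assay on THP-1 cells (Homo sapiens) for cytotoxicity (on this read-out lower numbers stand for higher toxicity in this test and higher numbers for lower toxicity in this test), compound 1 gives > 50000 nM, which is a limit of the assay and not a number. Compound 2 `COCc1ccc2nc(-c3ccccn3)c(Nc3cccc(F)c3)n2c1` gives 16000 nM in this assay. Compound 3 `CN(C)Cc1ccc2nc(-c3ccccn3)c(Nc3cccc(F)c3)n2c1` returns > 50000 nM, again a limit of the assay rather than a number. Compound 4 `Cc1ccn2c(Nc3cccc(F)c3)c(-c3ccccn3)nc2c1` differs from compound 1 by methyl in place of hydrogen on an aromatic carbon. Among the compounds with values here, the steps that bear on it are the additions of groups to the same core: an at least 3.1-fold lower number from compound 1 to compound 2 (0.49 log units; beyond the scatter), whereas a step that the two limits leave unreadable from compound 1 to compound 3. Both cases sit against (the limit of > 50000 nM in this assay, at which 2 of the 3 values shown sit), so the outcome of adding a single carbon without donors or acceptors cannot be read sharply from them. A methyl is a smaller addition than either the methoxymethyl or the (dimethylamino)methyl, and compound 4 is therefore expected to remain near the starting point, with an at least 1.2-fold lower number from compound 1 to compound 4 (0.09 log units; that floor lies within the scatter). The estimate for compound 4 is 40000 nM, in a range from 15000 nM to 100000 nM.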

Compound 4, half-maximal cytotoxic concentration: 14200 nM
The estimate for compound 4 lay 2.8-fold (0.45 log units) above the measured number; the whole stated range lies above it.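

In this assay, methyl on this aromatic carbon gives an at least 3.5-fold lower number from compound 1 to compound 4 (0.54 log units; beyond the scatter), so a single added carbon with no hydrogen-bond donors or acceptors is enough to move the read-out beyond the scatter. Compound 3, with (dimethylamino)methyl, gives > 50000 nM, which is a limit of the assay, and its step from the unsubstituted core cannot be read, so a lower number cannot be claimed for every added group. The step to compound 4 gives only a floor for the change because the starting value is itself a limit of the assay: the limit of > 50000 nM in this assay, at which 2 of the 4 values shown sit.

From the compounds shown here alone, whether a longer chain such as ethyl would lower the number further at this carbon remains open. So does the outcome there for a primary amine or a carboxylic acid.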